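The source may hold more compounds than are shown below. What is called first, only, known or untested is meant among the compounds shown, and "the series" means these compounds.

Compound 1 `CC1(C)c2cc(Cl)ccc2C(=O)N1c1cncc(OC2CN(C(=O)c3ncccc3Cl)C2)c1`: 58%
Compound 2 `CC1(C)c2cc(Cl)ccc2C(=O)N1c1cncc(N2CCN(S(C)(=O)=O)CC2)c1`: 54%

In an ADME assay on the whole organism (Rattus norvegicus, strain Wister-Han) for pharmacokinetics, read by LC-MS, at a dose of 3 mg/kg by the oral route (a lower number here means that a smaller share of the oral dose reaches the circulation, a higher number that a larger share of the oral dose reaches the circulation), compound 1 gives 58%, which lies within the scatter of compound 2 at 54%. Compound 3 `Cn1cc(C(=O)N2CC(Oc3cncc(N4C(=O)c5ccc(Cl)cc5C4(C)C)c3)C2)cn1` keeps the core of compound 1 and changes one group on a carbonyl carbon whose other neighbours are an amide-type nitrogen in a ring: 1-methyl-1H-pyrazol-4-yl in place of 3-chloropyridin-2-yl on a carbonyl carbon. Among the compounds with values here, no measured pair shows this exchange, so the expectation rests on compound 1 at 58% alone. The expected change is a number 8 percentage points lower from compound 1 to compound 3 (within the scatter), a small fall that stays within the scatter. For compound 3 the estimated value is 50%, with an expected range of 30% to 70%.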

Compound 3, oral bioavailability: 60%
The estimate for compound 3 lay 10 percentage points below the measured number; measured number inside the range.
By their numbers in this assay, from the lowest: compounds 2, 1 and 3 (each within the scatter of the next).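

In this assay, 1-methyl-1H-pyrazol-4-yl in place of 3-chloropyridin-2-yl on a carbonyl carbon gives a number 2 percentage points higher from compound 1 to compound 3 (within the scatter), so at this position a five-membered aromatic ring with 2 hetero atoms and no chlorine serves as well as the six-membered ring. Within the data shown here, this is the first measured exchange at this position, and the group on the carbonyl carbon can differ this much without the number leaving the scatter. No measurement shown bears on what lies behind this result. Open, as far as these compounds go, is whether a group without an aromatic ring, such as a methyl or a morpholine, would hold the number at this position.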